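Propyl to 1-methylethenyl at the amine carbon of compound 3

This account rests on a few compounds, and the source may have more. Where it says the series, first, only, none or still open, it means among the compounds named here.

Compound 3 `CCCCN(CC)Cc1c(C(F)(F)F)nc2n(-c3c(C)cc(C)cc3C)c(Cl)cn12` stands highest of the three numbers in an assay on cells for displacement of a labelled ligand from corticotropin-releasing factor receptor 1 (Homo sapiens), with a stated time of 100 min (a lower number here means a stronger inhibitor, a higher number a weaker inhibitor), with 78 nM. Compound 1 `CCCN(CC1CC1)C(=O)c1c(C)nc2n(-c3c(C)cc(C)cc3C)c(Cl)cn12` gives 61 nM, within the scatter of compound 3. Going by the values given here, compound 2 `CCN(Cc1c(C(F)(F)F)nc2n(-c3c(C)cc(C)cc3C)c(Cl)cn12)CC1CC1` gives 9 nM; the single measured step at this position, an 8.7-fold higher number from compound 2 to compound 3 (0.94 log units; beyond the scatter), lies beyond the scatter. Compound 4 `C=C(C)CN(CC)Cc1c(C(F)(F)F)nc2n(-c3c(C)cc(C)cc3C)c(Cl)cn12` alters the same place: 1-methylethenyl in place of propyl on a saturated chain carbon bound to an amine nitrogen. Only the cyclopropyl-to-propyl step bears on it; it shows that a compact three-carbon group at this carbon reads lower than propyl, and the branched entering group is closer to that case, so a partial return toward compound 2 is expected, not a step beyond it. Compound 4 is therefore estimated at 30 nM in this assay, a step of a 2.6-fold lower number from compound 3 to compound 4 (0.41 log units; beyond the scatter), with a range from 12 nM to 80 nM.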

Compound 4, inhibition constant: 67 nM
Estimate against measurement, compound 4: 2.2-fold (0.35 log units) below, and the stated range covers the measured number.
By their numbers in this assay, from the lowest: compound 2; then compounds 1, 4 and 3 (each within the scatter of the next).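

In this assay the change to 1-methylethenyl gives a 1.2-fold lower number from compound 3 to compound 4 (0.07 log units; within the scatter) and so leaves the number within the scatter of the propyl case; the double bond and branching bring no readable change at this place. The cyclopropyl case stays apart, with a 7.4-fold higher number from compound 2 to compound 4 (0.87 log units; beyond the scatter) beyond the scatter, so neither open-chain group tested here reaches compound 2. Nothing measured here explains this separation. Still open, on these data alone, is whether the lower number of compound 2 depends on the ring itself. Cyclobutyl or 2-methylpropyl at this place would test that.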